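The compounds below may be only part of what the source reports. "The series", "measured", "known", "first", "only" and "open" are said of these compounds alone.

Measured compounds:
compound 1, `Cn1c(=O)c2c(cc(/C=C/c3ccc(C(F)(F)F)cc3)n2C)n(C)c1=O`: 432 nM in an assay on isolated protein for inhibition of Amine oxidase [flavin-containing] B (Homo sapiens), read by luminescence, with a stated time of 1 h; a lower number here means a stronger inhibitor, a higher number a weaker inhibitor
compound 2, `Cn1c(=O)c2c(cc(/C=C/c3cccc(N)n3)n2C)n(C)c1=O`: > 10000 nM in this assay

Compound 1 gives a measured number in this assay. For compound 2, however, the result is only a limit, > 10000 nM, not a number. Compound 2 thus sits at the limit of > 10000 nM in this assay, at which 1 of the 2 values shown sits, and its true value can lie anywhere beyond it.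

Compound 3, `Cn1c(=O)c2c(cc(/C=C/c3cccc(O)c3)n2C)n(C)c1=O`, has not yet been measured in this assay. It differs from compound 2 in one place: 3-hydroxyphenyl in place of 6-aminopyridin-2-yl on a double-bonded chain carbon bound to a double-bonded chain carbon. Among the measured compounds shown here, the ring that enters is a plain carbon ring like the one in compound 1, whereas the ring that leaves is the one that went with the limit of compound 2. For the measured compounds named here, with no measured step of this kind to lean on, the size of the change is uncertain, but a step toward stronger inhibition, beyond the usual scatter, is expected from compound 2 to compound 3, an at least 6.6-fold lower number from compound 2 to compound 3 (0.82 log units; beyond the scatter). Compound 3 is therefore estimated at 1500 nM, with a range from 300 nM to 8000 nM.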

Compound 3, half-maximal inhibitory concentration: > 1000 nM
Compound 3: a limit, no number (the forecaster's own chance of this, stated with the estimate: 20%); the middle value lies beyond the limit too.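

Among the compounds shown here, compound 2 and compound 3 each give only a limit in this assay, not a number, and no step between them can be read. Still open, on these data alone, is how strongly each one truly inhibits, and whether 3-hydroxyphenyl or 6-aminopyridin-2-yl gives the stronger inhibitor.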